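Cyclopropyl for methyl on the aryl ether chain: second instance

A few compounds are considered here, and "the series" means these few. Any claim that something is new, unique, unknown or untested is made for them only; others in the source may bear on it.

Compound 1 `CCOc1cccc(-c2cccc(COc3ccc(OCC(=O)O)c(F)c3)c2)c1` serves as the reference of this set. In a functional assay on CHO cells for agonist activity at Free fatty acid receptor 1 (Homo sapiens), read by FLIPR and calcium flux (on this read-out higher numbers stand for an effect only at larger amounts of compound and lower numbers for an effect already at smaller amounts), compound 1 gives 480 nM. Compound 2 `O=C(O)COc1ccc(OCc2cccc(-c3cccc(OCC4CC4)c3)c2)cc1F` carries the change cyclopropyl in place of methyl on a saturated chain carbon bound to an oxygen on an aromatic ring and in this assay compound 2 gives 670 nM; the step is a 1.4-fold higher number from compound 1 to compound 2 (0.14 log units; within the scatter). Compound 3 `CCOc1ccc(-c2cccc(COc3ccc(OCC(=O)O)c(F)c3)c2)cc1` differs from compound 1 by 4-ethoxyphenyl in place of 3-ethoxyphenyl on an aromatic carbon and in this assay compound 3 gives 360 nM; the step is a 1.3-fold lower number from compound 1 to compound 3 (0.12 log units; within the scatter). The three numbers all lie within the scatter of one another, so no order among compounds 1, 2 and 3 can be drawn.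

Compound 4 `O=C(O)COc1ccc(OCc2cccc(-c3ccc(OCC4CC4)cc3)c2)cc1F` is not yet measured. It relates to compound 3 as compound 2 relates to compound 1, by cyclopropyl in place of methyl on a saturated chain carbon bound to an oxygen on an aromatic ring; the place of the change is the same in both pairs, and the two cores differ as described for compound 3 against compound 1. The earlier step was small, so a similar small step is expected here: compound 4 is estimated at 480 nM, within 240 nM to 950 nM, because compound 3 gives 360 nM and the expected step is a 1.3-fold higher number from compound 3 to compound 4 (0.12 log units; within the scatter).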

Compound 4, half-maximal effective concentration: 540 nM
Estimate against measurement, compound 4: 1.1-fold (0.05 log units) below, within the range that was stated.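

Carried to the second core, cyclopropyl in place of methyl gives a 1.5-fold higher number from compound 3 to compound 4 (0.18 log units; within the scatter) in this assay. The two instances of the change agree with each other: the same change on two cores in this assay, a 1.4-fold higher number (0.14 log units; within the scatter) from compound 1 to compound 2 and a 1.5-fold higher number (0.18 log units; within the scatter) from compound 3 to compound 4, 1.1-fold (0.03 log units) apart, within the scatter of two such steps. The change, ethoxy to cyclopropylmethoxy, thus carries between these two cores without a step beyond the scatter, but it does not show a real shift in either direction, and the two cores differ only as 3-ethoxyphenyl and 4-ethoxyphenyl do, so nothing follows for a core that differs elsewhere.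

Going by these compounds, it remains open whether a larger ring such as cyclohexyl, a longer chain or an amine on the same saturated chain carbon bound to an oxygen on an aromatic ring would give a step beyond the scatter. On these data alone, it also remains open whether the agreement between the two steps would hold on a core in which an amide takes the place of the ether link.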